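The source may report more compounds than this note shows. Statements on the series, on what has been measured and on what is new or still open speak of the compounds shown alone.

Among the measured compounds shown here, in an ADME assay on cells (Hepatocyte, Homo sapiens) for metabolic stability, with a stated time of 30 min (a higher number here means that more of the compound is left, a lower number that less of the compound is left), compound 2 (`O=C(OC1CCC(CN2CCN(c3cc(=O)c4cc(C(F)(F)F)cc([N+](=O)[O-])c4s3)CC2)CC1)c1ccncc1`) gives 1%, the lower of the two numbers so far, while compound 1 (`O=c1cc(N2CCN(CC3CCC(NS(=O)(=O)c4ccccc4)CC3)CC2)sc2c([N+](=O)[O-])cc(C(F)(F)F)cc12`) gives 90.8%. For the measured compounds named here, the one measured step, a number 89.8 percentage points lower from compound 1 to compound 2 (beyond the scatter), is large and beyond the scatter. It replaces (phenylsulfonyl)amino with ((pyridin-4-yl)carbonyl)oxy on a saturated ring carbon. Compound 3 (`O=C(OC1CCC(CN2CCN(c3cc(=O)c4cc(C(F)(F)F)cc([N+](=O)[O-])c4s3)CC2)CC1)c1ccco1`) differs from compound 2 by furan-2-yl in place of pyridin-4-yl on a carbonyl carbon. It keeps the oxygen next to a carbonyl group, so the large step does not cover this change: it exchanges the whole group, whereas here only the furan-2-yl and pyridin-4-yl groups differ. Going by the values given here, no measured step isolates a change on this carbonyl carbon, so the size of the step remains uncertain. A small upward step, not beyond the scatter, is expected in this assay, given the retained linkage and the value of compound 2 at 1%. The expected step is a number 2 percentage points higher from compound 2 to compound 3 (within the scatter). For compound 3 the estimated value is 3%, with an expected range of 0% to 15%.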

Compound 3, percent of the compound remaining: 1%
Compound 3: the middle estimate sits 2 percentage points above what was measured; the measured number falls inside the stated range.
By their numbers in this assay, from the lowest: compounds 2 and 3 (each within the scatter of the next); then compound 1.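

In this assay, furan-2-yl in place of pyridin-4-yl on the carbonyl carbon gives no change at the digits printed from compound 2 to compound 3 (within the scatter), so these two aromatic rings are not told apart at this position. Set against the sulfonamide side, ((furan-2-yl)carbonyl)oxy in place of (phenylsulfonyl)amino on a saturated ring carbon gives a number 89.8 percentage points lower from compound 1 to compound 3 (beyond the scatter), so the large drop is not specific to pyridin-4-yl and recurs with a second aromatic ring on the carbonyl carbon. Nothing measured explains this drop.

Still open, going by these compounds, is whether the drop follows the oxygen next to the carbonyl group or the loss of (phenylsulfonyl)amino; a ((furan-2-yl)carbonyl)amino group on the same saturated ring carbon would separate the two. With compounds 2 and 3 both this low, any difference between groups on the carbonyl carbon may also stay hidden.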